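A few compounds are considered here, and "the series" means these few. Any claim that something is new, unique, unknown or untested is made for them only; others in the source may bear on it.

Working notes on the hydroxamic acid series.

Of the compounds shown here, three have numbers so far. Compound 2 `COc1cc2c(Oc3ccc(NC(=O)c4nn(-c5ccc(C)cc5C)cc(C)c4=O)cc3)ccnc2cc1OCCCCCCC(=O)NO` gives 440 nM in a functional assay on HCT-116 cells (Homo sapiens) for inhibition, read by MTT assay, with a stated time of 72 h; on this read-out higher numbers stand for weaker inhibition and lower numbers for stronger inhibition. For the measured compounds named here, compound 1 `COc1cc2c(Oc3ccc(NC(=O)c4nn(-c5ccccc5)cc(C)c4=O)cc3F)ccnc2cc1OCCCC(=O)NO` gives 660 nM in this assay, a number that lies within the scatter of the one for compound 2, so the two are not told apart on this read-out. Going by the values given here, compound 3 `COc1cc2c(Oc3ccc(NC(=O)c4nn(-c5ccccc5C)ccc4=O)cc3F)ccnc2cc1OCCCC(=O)NO` gives 3980 nM in this assay, which stands well beyond the scatter from compound 2 and is the only clearly separated number in the set. Compound 3 differs from compound 2 in several places at once, so what its weaker number says about any one of those places cannot be read off here.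

Compound 4 `COc1cc2c(Oc3ccc(NC(=O)c4nn(-c5ccccc5C)cc(C)c4=O)cc3)ccnc2cc1OCCCCCCC(=O)NO` has not been measured. It is compound 2 with one change, (hydrogen in place of methyl on an aromatic carbon). Among the compounds with values here, no measured pair carries exactly this change, so its effect is not anchored by a step between known numbers. Within the data shown here, with compound 2 at 440 nM and no close precedent, the step from compound 2 to compound 4 is expected to be small, a 1.6-fold higher number from compound 2 to compound 4 (0.20 log units; within the scatter), with a slight lean toward a higher number but nothing that must exceed the scatter. Compound 4 is therefore estimated at 700 nM in this assay, with a range from 300 nM to 1800 nM.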

Compound 4, half-maximal inhibitory concentration: 660 nM
The estimate for compound 4 lay 1.1-fold (0.03 log units) above the measured number, within the range that was stated.
By their numbers in this assay, from the lowest: compounds 2, 1 and 4 (each within the scatter of the next); then compound 3.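

For the compounds shown here, this is the first step between compounds that differ in one place, and it can be read directly in this assay: going from 2,4-dimethylphenyl to 2-methylphenyl gives a 1.5-fold higher number from compound 2 to compound 4 (0.18 log units; within the scatter). Compound 2 and compound 4 are therefore not told apart on this read-out, so the methyl group on this aromatic carbon, para to a large group and meta to a methyl group, can give way to hydrogen without a change that exceeds the scatter. No accompanying measurement bears on this result, and the step stands as an observation without an explanation.

Still open, on these data alone, is whether a methoxy group, an amine or a carboxylic acid on this same carbon would give a number beyond the scatter, as this single step covers only methyl and hydrogen. The separate contributions of the methyl group that remains on the ring, the ring fluorine and the chain length also remain unresolved, as compound 1 and compound 3 each differ from compound 4 in several places.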